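A few compounds are considered here, and "the series" means these few. Any claim that something is new, unique, unknown or untested is made for them only; others in the source may bear on it.

Measured compounds: compound 1 `CCOC(=O)C1=C(C)NC(=S)NC1c1cn(C(=O)CNc2ccc([N+](=O)[O-])c(Cl)c2)c2ccccc12` with 3.4 in a physicochemical assay for lipophilicity; a lower number here means a more polar compound, a higher number a more lipophilic compound; compound 2 `CCOC(=O)C1=C(C)NC(=S)NC1c1cn(C(=O)CNc2ccc([N+](=O)[O-])cc2C)c2ccccc12` with 3.34; compound 3 `CCOC(=O)C1=C(C)NC(=S)NC1c1cn(C(=O)CNc2ccc(Cl)cc2)c2ccccc12` with 3.44.

Among these three, compound 3 gives the highest number, yet none of the gaps is telling: the step of a number 0.04 log units higher from compound 1 to compound 3 (within the scatter) and the step of a number 0.10 log units higher from compound 2 to compound 3 (within the scatter) both sit within the scatter, as does the step of a number 0.06 log units lower from compound 1 to compound 2 (within the scatter). The three aryl groups on the amine nitrogen, then, have so far been indistinguishable in this assay.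

Compound 4 `CCOC(=O)C1=C(C)NC(=S)NC1c1cn(C(=O)CNc2ccc([N+](=O)[O-])cc2)c2ccccc12` is the next member. Its change from compound 3 is nitro in place of chloro on an aromatic carbon. The measured steps that bear on this change are those in which a ring carrying a nitro group was exchanged for the 4-chlorophenyl ring, from compound 1 and from compound 2 to compound 3, and both were within the scatter. The reverse exchange in compound 4 is therefore expected to produce no step beyond the scatter, and the step of a number 0.14 log units lower from compound 3 to compound 4 (within the scatter) is the expected outcome. Compound 4 is accordingly estimated at 3.3 in this assay, with an expected range from 2.9 to 3.7.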

Compound 4, partition coefficient: 2.88
Beside the measured number, compound 4's estimate is 0.42 log units above it; measured number outside the range, below it.
By their numbers in this assay, from the lowest: compound 4; then compounds 2, 1 and 3 (each within the scatter of the next).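

In this assay, going by these compounds alone, the group on this aromatic carbon, para to a large group, does matter: nitro in place of chloro gives a number 0.56 log units lower from compound 3 to compound 4 (beyond the scatter) and is thus the first single change to move the number beyond the scatter. The other two steps show that this holds only for the 4-nitrophenyl ring carrying no further group, since hydrogen in place of methyl gives a number 0.46 log units lower from compound 2 to compound 4 (beyond the scatter) and hydrogen in place of chloro gives a number 0.52 log units lower from compound 1 to compound 4 (beyond the scatter) while compounds 1, 2 and 3 remain within the scatter of each other. The earlier steps had therefore suggested an indifference that belonged to the two more substituted nitro rings and not to the nitro group as such, and nothing available here bears on the reason for this.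

Still open, as far as these compounds go, is whether another group on the same carbon, such as a nitrile, a methoxy group or a carboxylic acid, would fall with nitro or with chloro. Also open, from the compounds shown here alone, is whether a smaller second group on the nitro ring, such as fluoro, would lift the number as methyl and chloro do, and whether a second group on the 4-chlorophenyl ring would leave it unchanged.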